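The compounds below may be only part of what the source reports. "The series", "measured", "known", "first", "only" and "open" are said of these compounds alone.

In a functional assay on HeLa cells (Homo sapiens) for antiproliferative activity (on this read-out higher numbers stand for weaker inhibition and lower numbers for stronger inhibition), compound 1 `CCONC(=O)c1sc(N2N=C(c3ccc(C)cc3)CC2c2cc3cc(OC)ccc3nc2Cl)nc1C` gives 38 nM, compound 2 `COc1ccc2nc(Cl)c(C3CC(c4ccc(C)cc4)=NN3c3nc(-c4ccc(Cl)cc4)cs3)cc2c1` gives 38 nM, and compound 3 `CNC(=O)c1sc(N2N=C(c3ccc(C)cc3)CC2c2cc3cc(OC)ccc3nc2Cl)nc1C` gives 38 nM. Compound 3 therefore stands level with the other two, and these numbers do not separate the three.

The next molecule, compound 4 `COc1ccc2nc(Cl)c(C3CC(c4ccc(C)cc4)=NN3c3nc(-c4ccc(C)cc4)cs3)cc2c1`, has not yet been measured. It keeps the shared core of compound 3 and changes only the group on an amine nitrogen in a ring: 4-(4-methylphenyl)-1,3-thiazol-2-yl in place of 4-methyl-5-(methylcarbamoyl)-1,3-thiazol-2-yl on an amine nitrogen in a ring. In plain terms, 4-(4-methylphenyl)-1,3-thiazol-2-yl replaces 4-methyl-5-(methylcarbamoyl)-1,3-thiazol-2-yl.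

Two measured swaps at this same place bear on the question. Putting 4-(4-chlorophenyl)-1,3-thiazol-2-yl in place of 5-(ethoxycarbamoyl)-4-methyl-1,3-thiazol-2-yl gave no change at the digits printed from compound 1 to compound 2 (within the scatter). The swap in the opposite sense, back to the group carried by compound 3, gave no change at the digits printed from compound 2 to compound 3 (within the scatter). A smaller edit on the amide-type nitrogen gave no change at the digits printed from compound 1 to compound 3 (within the scatter).

For the measured compounds named here, no measured compound carries the entering group itself, so this remains an inference from related groups. Even so, no step beyond the scatter is expected in this assay, in either direction. The expected step is no change at the digits printed from compound 3 to compound 4 (within the scatter). The estimated value for compound 4 is 38 nM, with an expected range from 17 nM to 85 nM.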

Compound 4, half-maximal inhibitory concentration: 38 nM
Estimate against measurement, compound 4: no gap at the digits printed; measured number inside the range.
By their numbers in this assay, from the lowest: compounds 1, 2, 3 and 4 (each within the scatter of the next).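

For the compounds shown here, compound 4 is the first compound here with a methyl-bearing phenyl on the thiazole, and in this assay placing 4-(4-methylphenyl)-1,3-thiazol-2-yl on the amine nitrogen in the ring, where 4-methyl-5-(methylcarbamoyl)-1,3-thiazol-2-yl stood, gives no change at the digits printed from compound 3 to compound 4 (within the scatter), although the entering group has no hydrogen-bond donor and the leaving group has one. The same holds against the ethoxy amide, with no change at the digits printed from compound 1 to compound 4 (within the scatter). The result also adds an edit on the outer aromatic ring itself: methyl in place of chloro on an aromatic carbon gives no change at the digits printed from compound 2 to compound 4 (within the scatter), so these two substituents on that ring cannot be told apart in this read-out.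

The compounds shown leave open whether any group at this place can move the value at all, for instance a carboxylic acid or an amine in place of the methyl on that phenyl ring, or a longer chain such as butyl. No supporting measurement is available to explain why these different groups read alike.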